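The source may report more compounds than this note shows. Statements on the series, on what has been measured and on what is new or still open speak of the compounds shown alone.

Compound 1, `CC/C=C\C/C=C\C/C=C\CCCCCCCc1cc(=O)c2c(O)cc(OCOC)c(C)c2o1`, gives 17500 nM in a functional assay on MCF7 cells (Homo sapiens) for antiproliferative activity, read by MTT assay; on this read-out higher numbers stand for weaker inhibition and lower numbers for stronger inhibition.
Compound 2, `CC/C=C\C/C=C\C/C=C\CCCCCCCc1cc(=O)c2c(O)cc(OCOC)cc2o1`, gives 17500 nM in this assay.
Compound 3, `CC/C=C\C/C=C\C/C=C\CCCCCCCc1cc(=O)c2c(O)c(C)c(O)c(C)c2o1`, gives 17500 nM in this assay.

All three measured compounds share the same long unsaturated chain on the same bicyclic core and sit at the same level in this assay. From compound 1 to compound 2 the change is hydrogen in place of methyl on an aromatic carbon, and the step is no change at the digits printed from compound 1 to compound 2 (within the scatter). How the core of compound 3 differs from the core of compound 1 is not broken down here. Compound 4, `CC/C=C\C/C=C\C/C=C\CCCCCCCc1cc(=O)c2c(O)c(C)c(O)cc2o1`, is not yet measured; it differs from compound 3 by hydrogen in place of methyl on an aromatic carbon, the same kind of change as that from compound 1 to compound 2, though here the carbon is ortho to a hydroxy group and meta to a methyl group rather than ortho to a methoxymethoxy group. Because the step of no change at the digits printed from compound 1 to compound 2 (within the scatter) lies within the scatter, compound 4 is expected to stay level with compound 3, a step of about no change at the digits printed from compound 3 to compound 4 (within the scatter). The estimate for compound 4 in this assay is 17500 nM, expected to fall between 9000 nM and 35000 nM.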

Compound 4, half-maximal inhibitory concentration: 17500 nM
The estimate for compound 4 equals the measured number at the digits printed; low and high end bracket the measured number.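

In this assay, replacing methyl with hydrogen on an aromatic carbon gives a step of no change at the digits printed from compound 3 to compound 4 (within the scatter). Set beside the earlier step on the other core, the change carries across these two cores with no difference beyond the scatter: the same change on two cores in this assay, no change at the digits printed (within the scatter) from compound 1 to compound 2 and no change at the digits printed (within the scatter) from compound 3 to compound 4, 1.0-fold (0.00 log units) apart, within the scatter of two such steps

For the compounds shown here, this shows only that the change left the read-out level on both cores; since neither step moved the value, it does not show that a change of measurable size would carry over, and it covers only two cores in one assay.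

The compounds shown leave open whether an ethyl group or a chlorine atom on that aromatic carbon would shift the value. They also leave open whether a shorter saturated chain or a chain ending in a carboxylic acid would do so.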